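A few compounds are considered here, and "the series" means these few. Any claim that something is new, unique, unknown or untested is made for them only; others in the source may bear on it.

Compound 1 `COc1cc(Oc2cccc(Nc3ccccc3)c2)cc(OC)c1CNCc1ccccc1` in a functional assay on SW-620 cells (Homo sapiens) for inhibition, read by MTT assay, with a stated time of 72 h; on this read-out higher numbers stand for weaker inhibition and lower numbers for stronger inhibition: 7490 nM
Compound 2 `COc1cc(Oc2cccc(Nc3ccccc3)c2)cc(OC)c1CNCCNC(C)=O`: 11900 nM
Compound 3 `COc1cc(Oc2cccc(Nc3ccccc3)c2)cc(OC)c1CNCc1ccc(Cl)cc1`: 6340 nM

These three compounds share a core and differ only in the group carried on the amine nitrogen. Their values lie close together, as a 1.2-fold lower number from compound 1 to compound 3 (0.07 log units; within the scatter) and a 1.9-fold lower number from compound 2 to compound 3 (0.27 log units; within the scatter) show. Compound 3 therefore holds no clear rank among them.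

Compound 4 `COc1cc(Oc2cccc(Nc3ccccc3)c2)cc(OC)c1CCO` makes a deeper change, with hydroxymethyl in place of (4-chlorobenzyl)amino on a saturated chain carbon bound to an aromatic carbon. The side chain thus ends in 2-hydroxyethyl, and the amine nitrogen is gone.

The nearest evidence comes from the measured swaps on that nitrogen. Putting acetamidomethyl in place of phenyl gave a 1.6-fold higher number from compound 1 to compound 2 (0.20 log units; within the scatter), and adding chloro gave a 1.2-fold lower number from compound 1 to compound 3 (0.07 log units; within the scatter). Among the compounds with values here, these swaps left the nitrogen in place, and no measured step removes it, so they can only loosely guide this prediction. Since this change is larger than any of them, a modest move toward weaker inhibition in this assay is expected, though with little certainty. The expected step is a 2.1-fold higher number from compound 3 to compound 4 (0.31 log units; beyond the scatter). The estimate for compound 4 is 13000 nM, with an expected range of 4500 nM to 40000 nM.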

Compound 4, half-maximal inhibitory concentration: > 20000 nM
Compound 4 gave a limit, no number; the forecaster's own chance of this, stated with the estimate: 20%; middle value at least 1.5-fold (0.18 log units) away from the limit.
By their numbers in this assay, from the lowest: compounds 3, 1 and 2 (each within the scatter of the next). At a limit, above all of these: compound 4.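

In this assay, compound 4 gives > 20000 nM, which is a limit of the assay and not a number. Changes to the group on the amine nitrogen had stayed within the scatter, whereas replacing the whole amine end of the side chain with 2-hydroxyethyl gives a clear loss of inhibition, seen as an at least 3.1-fold higher number from compound 3 to compound 4 (0.49 log units; beyond the scatter) and as an at least 2.6-fold higher number from compound 1 to compound 4 (0.42 log units; beyond the scatter). The third comparison, an at least 1.6-fold higher number from compound 2 to compound 4 (0.22 log units; that floor lies within the scatter), is less decisive, as its floor lies within the scatter, so compound 2 cannot yet be separated from compound 4, and the loss is firm only against the two benzyl-type amines, compound 1 and compound 3.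

This change removes the nitrogen and the aromatic ring together, and the compounds shown cannot tell which loss matters, although compound 2 has no such ring and still gives a number, 11900 nM. A small amine on the same chain, such as a dimethylamino group, would keep the nitrogen without the ring, while a carboxylic acid or a longer chain ending in hydroxyl would test other ends for the side chain.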